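A few compounds are considered here, and "the series" means these few. Any claim that something is new, unique, unknown or untested is made for them only; others in the source may bear on it.

In a functional assay on MCF cells (Homo sapiens) for antiproliferative activity, with a stated time of 72 h (on this read-out lower numbers stand for stronger inhibition and higher numbers for weaker inhibition), compound 1 `OC[C@H]1O[C@@H](n2cnc3c(NCc4ccc(F)cc4)ncnc32)[C@H](O)[C@@H]1O` gives 21000 nM and compound 2 `OC[C@H]1O[C@@H](n2cnc3c(NCc4ccc(Cl)c(Cl)c4)ncnc32)[C@H](O)[C@@H]1O` gives 88800 nM. Compound 3 `OC[C@H]1O[C@@H](n2cnc3c(NCc4c(F)ccc(F)c4F)ncnc32)[C@H](O)[C@@H]1O` gives only a limit of the assay, > 166000 nM, and not a true number. Compound 4 `OC[C@H]1O[C@@H](n2cnc3c(NCc4ccc(F)cc4Cl)ncnc32)[C@H](O)[C@@H]1O` differs from compound 3 in one group: 2-chloro-4-fluorophenyl in place of 2,3,6-trifluorophenyl on a saturated chain carbon bound to a nitrogen on an aromatic ring.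

Two measured steps away from the 4-fluorophenyl group bear on this change, and both weakened inhibition: a 4.2-fold higher number from compound 1 to compound 2 (0.63 log units; beyond the scatter) and an at least 7.9-fold higher number from compound 1 to compound 3 (0.89 log units; beyond the scatter). The 2-chloro-4-fluorophenyl group of compound 4 keeps the 4-fluoro of compound 1, which gives 21000 nM, so stronger inhibition than in compound 3 is expected. The expected change is an at least 3.3-fold lower number from compound 3 to compound 4 (0.52 log units; beyond the scatter). For compound 4, the estimated value is 50000 nM, with an expected range from 17000 nM to 150000 nM.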

Compound 4, half-maximal inhibitory concentration: > 166000 nM
Compound 4: only a limit was reported; the forecaster's own chance of this, stated with the estimate: 20%; middle value at least 3.3-fold (0.52 log units) away from the limit.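

In this assay, keeping the 4-fluoro does not preserve inhibition: chloro in place of hydrogen on an aromatic carbon gives an at least 7.9-fold higher number from compound 1 to compound 4 (0.89 log units; beyond the scatter). The comparison with the 3,4-dichlorophenyl group gives an at least 1.8-fold higher number from compound 2 to compound 4 (0.27 log units; that floor lies within the scatter), so compound 4 cannot be firmly ranked against compound 2. The step between compound 3 and compound 4 cannot be read, since both values are limits: the limit of > 166000 nM in this assay, at which 2 of the 4 values shown sit.

On these data alone, whether an unsubstituted phenyl or a 4-methoxyphenyl group in this place would restore inhibition stays open. So does the true value of compound 3 or compound 4.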